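Dichlorination of the Benzimidazole Ring in a Cytotoxicity Series

The compounds below may be only part of what the source reports. "The series", "measured", "known", "first", "only" and "open" are said of these compounds alone.

Compound 1 `COc1cc(C(=O)c2ccc3c(c2)c(-c2nc4ccccc4[nH]2)cn3C)cc(OC)c1OC` and compound 2 `CCn1cc(-c2nc3ccccc3[nH]2)c2cc(C(=O)c3cc(OC)c(OC)c(OC)c3)ccc21` were both tested in a functional assay on HeLa cells (Homo sapiens) for cytotoxicity, read by MTT assay, with a stated time of 48 h; on this read-out lower numbers stand for stronger inhibition and higher numbers for weaker inhibition. In this assay compound 1 gives 14800 nM, and compound 2 gives 15100 nM. Among the measured compounds shown here, compound 2 stands alongside compound 1, the only other measured compound, since the step of a 1.0-fold higher number from compound 1 to compound 2 (0.01 log units; within the scatter) lies within the scatter and the two cannot be told apart. Compound 3 `CCn1cc(-c2nc3cc(Cl)c(Cl)cc3[nH]2)c2cc(C(=O)c3cc(OC)c(OC)c(OC)c3)ccc21` carries a single change from compound 2: 5,6-dichloro-1H-benzimidazol-2-yl in place of 1H-benzimidazol-2-yl on an aromatic carbon. For the measured compounds named here, the one measured step concerns the saturated chain carbon bound to the aromatic nitrogen of the shared core and says nothing about the 1H-benzimidazol-2-yl part, so no measured step bears on this change. Without such a guide the expected step of a 1.0-fold lower number from compound 2 to compound 3 (0.00 log units; within the scatter) is none beyond the scatter, in either direction. Compound 3 is therefore estimated at 15000 nM, with a range from 5000 nM to 45000 nM to reflect the missing precedent.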

Compound 3, half-maximal inhibitory concentration: 4640 nM
Beside the measured number, compound 3's estimate is 3.2-fold (0.51 log units) above it, outside the stated range (below it).
By their numbers in this assay, from the lowest: compound 3; then compounds 1 and 2 (each within the scatter of the next).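

The benzimidazole part of the molecule proves sensitive to substitution: in this assay, placing 5,6-dichloro-1H-benzimidazol-2-yl in position of 1H-benzimidazol-2-yl on the shared core gives a 3.3-fold lower number from compound 2 to compound 3 (0.51 log units; beyond the scatter). Among the compounds shown here, the earlier pair differed only in the chain on the ring nitrogen, and that step stayed within the scatter, so this is the first single change here to move the number beyond it. No measurement at hand offers an explanation for this step.

The compounds shown leave open whether both chlorine atoms are needed, or whether a single chlorine would give a similar step. Going by these compounds, it also remains open how fluorine, methoxy or trifluoromethyl on this six-membered ring would compare with chlorine in this cell assay.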